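This account rests on a few compounds, and the source may have more. Where it says the series, first, only, none or still open, it means among the compounds named here.

Among the compounds with values here, compound 2 `Cc1ccc(NC(=O)C[C@H](CCC(=O)O)c2noc(-c3ccc(CC(C)C)cc3)c2C2CC2)c(Cl)c1` gives 4.8 in a physicochemical assay for lipophilicity (a higher number here means a more lipophilic compound, a lower number a more polar compound), the highest of the three numbers measured so far. Its nearest neighbour is compound 3 `Cc1ccc(NC(=O)C[C@H](CCC(=O)O)c2noc(-c3noc(CC(C)C)n3)c2C2CC2)c(Cl)c1`, which gives 3.6; furthest from it is compound 1 `Cc1ccc(NC(=O)CC(CCN)c2nnc(CCCC(C)C)n2C2CC2)c(C)c1`, which gives 3.1. Compound 4 `Cc1ccc(NC(=O)C[C@H](CCC(=O)O)c2noc(-c3cc(C(F)(F)C(C)(C)C)on3)c2C2CC2)c(Cl)c1` has not yet been measured in this assay. It differs from compound 2 in one place: 5-(1,1-difluoro-2,2-dimethylpropyl)-1,2-oxazol-3-yl in place of 4-isobutylphenyl on an aromatic carbon. Within the data shown here, the one measured step that bears on this change is a number 1.20 log units lower from compound 2 to compound 3 (beyond the scatter), where a six-membered aromatic ring of carbon only was likewise exchanged for a five-membered aromatic ring with hetero atoms. Compound 4 differs from compound 3 both in that five-membered ring and in the group carried on it, so the step is not expected to repeat exactly, yet a fall beyond the scatter in the same direction seems the likeliest outcome, probably somewhat smaller than the step to compound 3. For compound 4 the expected change is therefore a number 0.70 log units lower from compound 2 to compound 4 (beyond the scatter). Compound 4 is thus estimated at 4.1, with a range from 3.5 to 4.7 in this assay.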

Compound 4, distribution coefficient: 4.3
Compound 4: the middle estimate sits 0.20 log units below what was measured, within the range that was stated.
By their numbers in this assay, from the lowest: compound 1; then compound 3; then compound 4; then compound 2.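

In this assay the exchange of 4-isobutylphenyl for 5-(1,1-difluoro-2,2-dimethylpropyl)-1,2-oxazol-3-yl gives a number 0.50 log units lower from compound 2 to compound 4 (beyond the scatter) and so moves the same way as the earlier exchange that gave compound 3. The two five-membered replacements do not give the same number, and the gap between them is a number 0.70 log units higher from compound 3 to compound 4 (beyond the scatter) at this same position, so having a five-membered aromatic ring here does not by itself fix the read-out. Nothing shown explains either step.

Compound 3 and compound 4 differ both in the ring and in the group it carries, so the compounds shown do not divide the gap between these two parts. On these data alone, how a trifluoromethyl group or a nitrile on the 1,2-oxazol-3-yl ring would stand in this assay also remains open.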